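A few compounds are considered here, and "the series" means these few. Any claim that something is new, unique, unknown or untested is made for them only; others in the source may bear on it.

Working notes on the series, read in an ADME assay on MT4 cells (Homo sapiens) for cytotoxicity, read by MTT assay (a lower number here means that less compound is tolerated, a higher number that more compound is tolerated), and so far resting on two compounds. Compound 1 (`O=C(CSc1nc(Cc2c(Cl)cccc2Cl)cc(=O)[nH]1)c1ccc(F)cc1`) gives > 59000 nM as a limit and not as a number. Compound 2 (`O=C(CSc1nc(Cc2c(F)cccc2Cl)cc(=O)[nH]1)c1ccccc1`) gives > 13000 nM as a limit and not as a number. Compound 2 therefore has no exact position on the scale, and the two limits cannot be ranked against each other.

Compound 3 (`O=C(CSc1nc(Cc2c(F)cccc2Cl)cc(=O)[nH]1)c1ccc(F)cc1`) differs from compound 2 in one place: the phenyl of the benzoyl group becomes 4-fluorophenyl, with fluoro in place of hydrogen on an aromatic carbon. For the measured compounds named here, no measured step in this assay covers this change. The 4-fluorophenyl group is already present in compound 1, which shows no exact value either. The expectation is therefore no change beyond the usual scatter, with neither direction favoured, and a further limit is the most likely report. The expected step that the limit leaves unreadable from compound 2 to compound 3 is small. For compound 3 the estimated value is 20000 nM with an expected range from 9000 nM to 60000 nM in this assay.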

Compound 3, half-maximal cytotoxic concentration: > 61000 nM
Compound 3: only a limit was reported; the forecaster's own chance of this, stated with the estimate: 75%; middle value at least 3.0-fold (0.48 log units) from the limit.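

In this assay compound 3 gives > 61000 nM, a limit and not a number. Compound 1 and compound 2 also stand only as limits, so neither step to compound 3 can be read. The compounds shown leave open whether fluoro in place of hydrogen, or fluoro in place of chloro, on an aromatic carbon shifts the read-out at all.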